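This account rests on a few compounds, and the source may have more. Where it says the series, first, only, none or still open, it means among the compounds named here.

Compound 2 `c1coc(-c2nc3nc(NC4CCCCC4)nc(NC4CCCCC4)n3n2)c1` gives 129 nM in an assay on CHO cells for displacement of a labelled ligand from adenosine receptor A3 (Homo sapiens) (on this read-out higher numbers stand for weaker inhibition and lower numbers for stronger inhibition), the lowest of the two numbers recorded so far; compound 1 `CNc1nc(N)n2nc(-c3ccco3)nc2n1` gives 1560 nM, a gap that lies well beyond the scatter. Compound 3 `c1ccc(CNc2nc(NC3CCCCC3)n3nc(-c4ccco4)nc3n2)cc1` has not yet been measured. It differs from compound 2 in one place only: benzyl in place of cyclohexyl on a nitrogen on an aromatic ring. For the measured compounds named here, no step between measured compounds covers this kind of exchange, so its size has to be judged from the two structures alone. One six-membered carbon ring is traded for another, the second cyclohexylamino of compound 2 stays, and the core is unchanged, so no step beyond the scatter is expected in this assay in either direction, with at most a small shift. Compound 3 is therefore expected to give about 100 nM, between 30 nM and 350 nM. The expected step is a 1.3-fold lower number from compound 2 to compound 3 (0.11 log units; within the scatter).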

Compound 3, inhibition constant: 455 nM
Estimate against measurement, compound 3: 4.6-fold (0.66 log units) below, outside the stated range (above it).
By their numbers in this assay, from the lowest: compound 2; then compound 3; then compound 1.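

In this assay, the group on this nitrogen matters more than its shared six-membered carbon ring would suggest: the change from cyclohexylamino to benzylamino gives a 3.5-fold higher number from compound 2 to compound 3 (0.55 log units; beyond the scatter) in a modest step. Cyclohexyl and benzyl are therefore not interchangeable at this place, and the non-aromatic cyclohexyl goes with the lower number. Nothing available gives a measured reason for this difference.

The compounds shown leave open whether the step belongs to the aromatic ring itself or to the methylene link that joins it to the nitrogen, which a phenyl group or a cyclohexylmethyl group at this place would separate. They also leave open how a longer chain such as phenethyl, or an amine or a methoxy group on the benzyl ring, would read here.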